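Cyclopentyl to trifluoropropyl on the shared core

The compounds below may be only part of what the source reports. "The series", "measured", "known", "first", "only" and "open" are said of these compounds alone.

Compound 1 `CC[C@@H]1C(=O)N(C)c2cnc(-n3ccnc3-c3ccccc3)nc2N1C1CCCC1` is the reference. In an ADME assay on microsomes from liver (Rattus norvegicus) for metabolic stability, with a stated time of 30 min, tested at 1 uM (on this read-out higher numbers stand for a more stable compound and lower numbers for a less stable compound), compound 1 gives 0%; compound 2 `CC(C)N1c2nc(-n3ccnc3-c3ccc(F)cc3)ncc2N(C)C(=O)C1(C)C` gives 10%, and the two values sit within the usual scatter of each other, so neither is read as more stable. For the measured compounds named here, no pair of measured compounds differing in one place is available as a yardstick. Compound 3 `CC[C@@H]1C(=O)N(C)c2cnc(-n3ccnc3-c3ccccc3)nc2N1CCC(F)(F)F` carries the change (3,3,3-trifluoropropyl in place of cyclopentyl on a nitrogen on an aromatic ring in a ring). With both measured values at the low end of the read-out, the step in this assay is expected to be small, if anything upward, and may stay within the scatter: a number 15 percentage points higher from compound 1 to compound 3 (beyond the scatter). Compound 3 is estimated at 15% in this assay, with a range from 0% to 45%.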

Compound 3, percent of the compound remaining: 0%
Beside the measured number, compound 3's estimate is 15 percentage points above it; the measured number falls inside the stated range.
By their numbers in this assay, from the lowest: compounds 1, 3 and 2 (each within the scatter of the next).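

In this assay, for the compounds shown here, the step for 3,3,3-trifluoropropyl in place of cyclopentyl on this nitrogen reads no change at the digits printed from compound 1 to compound 3 (within the scatter), giving the only one-place comparison at this position. Compound 3 stays at 0%, so replacing the five-membered carbon ring with this open fluorinated chain does not move the read-out here. Nothing measured offers a reason for this result. From the compounds shown here alone, whether an amine or a longer chain at this nitrogen would raise the number remains open. So does whether this step would hold with the 4-fluorophenyl group of compound 2 on the core.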